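Methyl for methoxy on a slowly cleared compound

The compounds below may be only part of what the source reports. "The series", "measured", "known", "first", "only" and "open" are said of these compounds alone.

In a toxicity assay on microsomes from liver (Homo sapiens) for metabolic stability, read by LC-MS, using NADPH, tested at 1 uM (a lower number here means slower removal, a higher number faster removal of the compound), compound 1 (`Cc1nc(-c2nc3ccccc3[nH]2)c(N2CCN(C(=O)Cn3cnc4cccnc43)[C@H](C)C2)s1`) gives 23 mL.min-1.g-1, and compound 2 (`CCOc1ncc(-c2nc(C(F)(F)F)sc2N2CCN(C(=O)Cn3cnc4ccccc43)[C@H](C)C2)cn1`) gives 662 mL.min-1.g-1. Compound 3 (`COc1ncc(-c2nc(C(F)(F)F)sc2N2CCN(C(=O)Cn3nc(C)nc3C)[C@H](C)C2)cn1`) gives < 10 mL.min-1.g-1, which is a limit of the assay and not a number.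

Compound 4 (`Cc1ncc(-c2nc(C(F)(F)F)sc2N2CCN(C(=O)Cn3nc(C)nc3C)[C@H](C)C2)cn1`) differs from compound 3 in one place: methyl in place of methoxy on an aromatic carbon. The 2-methoxypyrimidin-5-yl of compound 3 thus becomes the 2-methylpyrimidin-5-yl of compound 4. Among the measured compounds shown here, no measured pair of compounds shows this change alone, so the expectation is loose: a small rise in this assay at most, perhaps nothing beyond the usual scatter. The expected step is a number no lower from compound 3 to compound 4 (the limit leaves the size open). For compound 4 the estimated value is 10 mL.min-1.g-1, with an expected range from 5 mL.min-1.g-1 to 30 mL.min-1.g-1.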

Compound 4, intrinsic clearance in microsomes: < 10 mL.min-1.g-1
Compound 4 gave a limit, no number; the forecaster's own chance of this, stated with the estimate: 55%; the middle value lies on the limit itself.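

In this assay, among the compounds shown here, compound 3 and compound 4 both give a limit rather than a number, so no step between them can be read: the limit of < 10 mL.min-1.g-1 in this assay, at which 2 of the 4 values shown sit.

The compounds shown leave open what methyl in place of methoxy does to a compound with a clearance high enough to read as a number.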